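Swapping ethoxycarbonyl for pyrimidin-2-yl on a shared core

The source may hold more compounds than are shown below. What is called first, only, known or untested is meant among the compounds shown, and "the series" means these compounds.

Of the compounds shown here, three built on the same core have been measured in an ADME assay on HeLa cells (Homo sapiens) for cytotoxicity, read by MTT assay, with a stated time of 24 h; on this read-out higher numbers stand for weaker inhibition and lower numbers for stronger inhibition. Compound 1 `CCOC(=O)N1CCN(C(=S)SC(=S)N(C)C)CC1` gives 530000 nM, the lowest of the three numbers. Compound 3 `CN(C)C(=S)SC(=S)N1CCN(c2cccc(Cl)c2Cl)CC1` gives 1590000 nM, a number higher than that of compound 1 by a margin that lies beyond the usual scatter of such measurements. Compound 2 `CN(C)C(=S)SC(=S)N1CCN(c2cccc(C(F)(F)F)c2)CC1` gives 2760000 nM, higher still, and again beyond the scatter relative to compound 1. For the measured compounds named here, no two of these three compounds differ in only one place, so no single step between measured compounds can be named.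

Compound 4 `CN(C)C(=S)SC(=S)N1CCN(c2ncccn2)CC1` has not yet been measured in this assay. It differs from compound 1 in one place: pyrimidin-2-yl in place of ethoxycarbonyl on an amine nitrogen in a ring. The two measured compounds that carry an aromatic ring on the same amine nitrogen, compound 2 and compound 3, both give higher numbers than compound 1, though neither carries the ring of compound 4 and the two shifts differ in size. On that basis a step toward a higher number is expected for compound 4, beyond the scatter yet smaller than the gap between compound 1 and compound 2. The expected step from compound 1 to compound 4 is a 2.3-fold higher number from compound 1 to compound 4 (0.35 log units; beyond the scatter). Compound 4 is therefore estimated at 1200000 nM, with a range from 500000 nM to 3000000 nM.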

Compound 4, half-maximal inhibitory concentration: > 5000000 nM
Compound 4: a limit, no number; the forecaster's own chance of this, stated with the estimate: 10%; middle value at least 4.1-fold (0.61 log units) from the limit.
By their numbers in this assay, from the lowest: compound 1; then compounds 3 and 2 (each within the scatter of the next). At a limit, above all of these: compound 4.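

In this assay compound 4 gives > 5000000 nM, which is a limit of the assay and not a number. Pyrimidin-2-yl in place of ethoxycarbonyl on an amine nitrogen in a ring gives an at least 9.4-fold higher number from compound 1 to compound 4 (0.97 log units; beyond the scatter), and this is the first step at this position that can be tied to one change alone, as no earlier pair differed in only one place. The step therefore shows that this single exchange on the shared core moves the number upward by a margin beyond the usual scatter, yet it gives only a lower bound on the size of that move, and how far the move extends cannot be read: the limit of > 5000000 nM in this assay, at which 1 of the 4 values shown sits.

The compounds shown leave open whether a plain phenyl ring on the same amine nitrogen, or an acetyl group or a longer alkoxycarbonyl chain in place of ethoxycarbonyl, would shift the number in the same direction. They also leave open whether the step belongs to the pyrimidin-2-yl ring as a whole or would persist with an amine or a methyl group added to that ring.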